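This account rests on a few compounds, and the source may have more. Where it says the series, first, only, none or still open, it means among the compounds named here.

Compound 1 `Cn1ccc(-n2c(=O)n(Cc3cc4cc(Cl)ccc4n3CCCC#N)c3cnccc32)n1`: in an ADME assay on HeLa cells (Homo sapiens) for cytotoxicity, read by ATP content, with a stated time of 3 days (a higher number here means that more compound is tolerated, a lower number that less compound is tolerated), compound 1 gives > 50000 nM, which is a limit of the assay and not a number.
Compound 2 `N#CCCCn1c(Cn2c(=O)n(-c3ncco3)c3ccncc32)cc2cc(Cl)ccc21`: compound 2 gives > 50000 nM, again a limit of the assay.
Compound 3 `COc1ccc(-n2c(=O)n(Cc3cc4cc(Cl)ccc4n3CCCC#N)c3cnccc32)c(C)c1`: compound 3 gives > 50000 nM, also a limit of the assay.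

On the numbers shown, compound 3 stands where the other two stand, at the limit of > 50000 nM in this assay, at which 3 of the 3 values shown sit; nothing separates the three. The three measured steps, a step that the two limits leave unreadable from compound 1 to compound 2, a step that the two limits leave unreadable from compound 1 to compound 3 and a step that the two limits leave unreadable from compound 2 to compound 3, are all unreadable, both ends of each sitting at the limit. Compound 4 `N#CCCCn1c(Cn2c(=O)n(-c3ccncn3)c3ccncc32)cc2cc(Cl)ccc21` differs from compound 3 in one place: pyrimidin-4-yl in place of 4-methoxy-2-methylphenyl on an aromatic nitrogen. The measured steps bear on this change in that each of them also swaps the group on the same aromatic nitrogen of the shared core, and none of them brought a reading out of the limit. In this assay no step beyond the scatter is therefore expected, in either direction. Compound 4 is expected to give 50000 nM, with a range from 25000 nM to 100000 nM, most probably reported again as a limit. The expected step is a number no higher from compound 3 to compound 4 (the limit leaves the size open), none beyond the scatter.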

Compound 4, half-maximal cytotoxic concentration: > 50000 nM
Compound 4: a limit, no number; the forecaster's own chance of this, stated with the estimate: 90%; the middle value lies on the limit itself.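

Compound 4 joins compound 1, compound 2 and compound 3 at a limit of this assay, so no new step to compound 4 can be read: the limit of > 50000 nM in this assay, at which 4 of the 4 values shown sit.

The compounds shown leave open how much of any of the four is tolerated, and whether the group on the aromatic nitrogen matters at all.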